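A Changed Acid-Bearing Ring in a Receptor Modulator Series

This account rests on a few compounds, and the source may have more. Where it says the series, first, only, none or still open, it means among the compounds named here.

Measured so far in an assay on HEK293 cells for positive allosteric modulation of metabotropic glutamate receptor 2 (Rattus norvegicus), read by thallium flux; on this read-out lower numbers stand for an effect already at smaller amounts and higher numbers for an effect only at larger amounts of compound:
Compound 1, `O=C(O)c1cc(-c2cccc(COc3ccc4c(=O)n(C5CC5)sc4c3)c2)ccc1Cl`, gives 130 nM.
Compound 2, `COc1ccc(-c2cccc(COc3ccc4c(c3)CN(C3CCCC3)C4=O)c2)cc1C(=O)O`, gives 170 nM.
Compound 3, `CN(C)C(=O)c1cc(-c2cccc(COc3ccc4c(=O)n(C5CCCC5)sc4c3)c2)ccc1Cl`, gives 980 nM.

Of these three numbers, compound 2 holds the second highest. Its nearest neighbour is compound 1, whose number is lower by an amount that lies within the usual scatter, so the two cannot be told apart. Compound 3 is the furthest away, with a number higher by an amount that lies beyond the scatter. No two of the measured compounds differ in only one place, so no single step can be read from them directly.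

Compound 4, `O=C(O)c1cc(F)cc(-c2cccc(COc3ccc4c(c3)CN(C3CCCC3)C4=O)c2)c1`, has not been measured. It differs from compound 2 in one place: 3-carboxy-5-fluorophenyl in place of 3-carboxy-4-methoxyphenyl on an aromatic carbon. Among the compounds with values here, since no measured pair shows the effect of such a change, the expectation rests on the closeness of compound 1 and compound 2, which carry differently substituted acid-bearing rings yet sit within the scatter of each other. The step of a 1.5-fold higher number from compound 2 to compound 4 (0.17 log units; within the scatter) is therefore expected to be small, if anything towards a slightly higher number, and not clearly beyond the scatter. Compound 4 is estimated at 250 nM, with a range from 80 nM to 800 nM.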

Compound 4, half-maximal effective concentration: 130 nM
For compound 4 the middle estimate is 1.9-fold (0.28 log units) above the measured one; the range from low to high includes it.
By their numbers in this assay, from the lowest: compounds 1, 4 and 2 (each within the scatter of the next); then compound 3.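

In this assay, within the data shown here, the replacement of 3-carboxy-4-methoxyphenyl by 3-carboxy-5-fluorophenyl gives a 1.3-fold lower number from compound 2 to compound 4 (0.12 log units; within the scatter) and is the first single change that can be read directly. On this shared core, the two rings cannot be told apart, so this position accepts both substitution patterns on the acid-bearing ring, though this rests on one pair alone. No measurement shown here accounts for this result.

Among these compounds, the single step swaps the methoxy and fluorine patterns together, so it remains open what each contributes alone. Also open, from the compounds shown here alone, is whether a ring carrying a nitrile or an amine in place of the fluorine would read the same, and whether a tetrazole could stand in for the carboxylic acid on this core.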